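The compounds below may be only part of what the source reports. "The series", "measured", "known", "first", "only" and "open" are said of these compounds alone.

Working notes on the series. Compound 2 `COc1cccc(CNCCCNc2ccnc3cc(-c4ccc(F)cc4)ccc23)c1O` sits level with compound 1 `Fc1ccc(-c2ccc3c(NCCCNCc4ccco4)ccnc3c2)cc1` in an ADME assay for permeability, using PAMPA, with a stated time of 30 min, at pH 7.4; a lower number here means that the compound crosses the layer more slowly, a higher number that the compound crosses the layer faster: compound 2 gives 237 10^-6 cm/s and compound 1 gives 237 10^-6 cm/s, and no change at the digits printed from compound 1 to compound 2 (within the scatter) when 2-hydroxy-3-methoxyphenyl replaces furan-2-yl on a saturated chain carbon bound to an amine nitrogen. Together these two are the highest of the three numbers so far. The third, compound 3 `CC(C)Cc1ccc2c(NCCCNCc3ccco3)ccnc2c1`, gives 23 10^-6 cm/s in this assay, and a 10-fold lower number from compound 1 to compound 3 (1.01 log units; beyond the scatter) with isobutyl in place of 4-fluorophenyl on an aromatic carbon.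

The unmeasured compound 4 `COc1cccc(Oc2ccc3c(NCCCNCc4cccc(OC)c4O)ccnc3c2)c1` differs from compound 2 as follows: 3-methoxyphenoxy in place of 4-fluorophenyl on an aromatic carbon. For the measured compounds named here, of the two measured steps only the one from compound 1 to compound 3 touches the 4-fluorophenyl, and there a 10-fold lower number from compound 1 to compound 3 (1.01 log units; beyond the scatter), a large drop, though the group that entered was isobutyl rather than an aromatic ring. The step from compound 1 to compound 2 shows that a change elsewhere on the molecule left this assay unchanged. Going by the values given here, no measured step exchanges 4-fluorophenyl for another aryl group, so the expectation rests on compound 3 alone and is held loosely: in this assay the step from compound 2 to compound 4 is expected to be a 2.0-fold lower number from compound 2 to compound 4 (0.30 log units; within the scatter), a moderate fall short of the drop seen for compound 3. Compound 4 is therefore estimated at 120 10^-6 cm/s in this assay, with a range of 40 10^-6 cm/s to 300 10^-6 cm/s.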

Compound 4, apparent permeability: 317 10^-6 cm/s
Estimate against measurement, compound 4: 2.6-fold (0.42 log units) below, outside the stated range (above it).
By their numbers in this assay, from the lowest: compound 3; then compounds 1, 2 and 4 (each within the scatter of the next).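

In this assay the exchange at this aromatic carbon gives a 1.3-fold higher number from compound 2 to compound 4 (0.13 log units; within the scatter), so 3-methoxyphenoxy, with 9 heavy atoms and 2 hydrogen-bond acceptors, is accepted here in place of 4-fluorophenyl, with 7 heavy atoms and 0 hydrogen-bond acceptors, without a step beyond the scatter. Until now the only step read at this position was a 10-fold lower number from compound 1 to compound 3 (1.01 log units; beyond the scatter), with isobutyl entering on the furan-2-yl side of the series, so the position is now shown to tolerate at least one change of aryl group, and the large step no longer stands as the only outcome there. No measurement offered here gives a reason for either step.

The two steps at this position start from different compounds, so what the compounds shown leave open is whether isobutyl would give a step of the same size on the 2-hydroxy-3-methoxyphenyl side, or 3-methoxyphenoxy the same result on the furan-2-yl side. Also open, on these data alone, is how this read-out responds when a group such as a carboxylic acid or a saturated amine stands on this aromatic carbon.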